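Compound 2 to Compound 4: A Cytotoxicity Estimate

This account rests on a few compounds, and the source may have more. Where it says the series, first, only, none or still open, it means among the compounds named here.

Compound 1 `CC(Nc1ccc(Cl)cc1Cl)C(=O)NCc1ccc(F)cc1`: > 100000 nM (a limit, not a number)
Compound 2 `CC(Oc1ccc(Cl)cc1Cl)C(=O)Nc1ccc(F)cc1`: "not determined" (no result reported)
Compound 3 `CC(Oc1ccc(Cl)cc1Cl)C(=O)N(C)Cc1ccc(F)cc1`: "not determined" (no result reported)

Compound 2 has no number to stand on in an ADME assay on CHO cells (Cricetulus griseus) for cytotoxicity, read by LDH release (on this read-out higher numbers stand for weaker inhibition and lower numbers for stronger inhibition), and neither does compound 3. Among the measured compounds shown here, compound 1 supplies the only reading in this assay, which is the limit of > 100000 nM in this assay, at which 1 of the 3 values shown sits.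

The step from compound 2 to compound 4 `CC(Oc1ccc(Cl)cc1Cl)C(=O)NCc1ccccc1` puts benzyl in place of 4-fluorophenyl on an amide-type nitrogen. For the measured compounds named here, no measured pair gives a size for this change, and without a number for compound 2 no size can be read from that side. In this assay the expectation is therefore a step in neither direction, and none beyond the usual scatter. This expectation rests on compound 1, whose reading of > 100000 nM is a limit of the assay. Compound 4 is expected near 100000 nM, with an estimated range from 30000 nM to 200000 nM.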

Compound 4, half-maximal inhibitory concentration: 95000 nM
Compound 4: the middle estimate sits 1.1-fold (0.02 log units) above what was measured, and the stated range covers the measured number.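

No step can be read from the result for compound 4, since neither compound 2 nor compound 3 carries a number to set beside it. The compounds shown leave open whether benzyl in place of 4-fluorophenyl on an amide-type nitrogen shifts the reading in this assay at all.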